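This account rests on a few compounds, and the source may have more. Where it says the series, first, only, none or still open, it means among the compounds named here.

Among the compounds with values here, compound 3 `N#CC1=C(N)Oc2c(c3nc4ccccc4nc3c3ccccc23)C12C(=O)N(Cc1cnnn1-c1cccc(S(N)(=O)=O)c1)c1ccccc12` gives 21500 nM in a functional assay on HepG2 cells (Homo sapiens) for antiproliferative activity, read by MTT assay, with a stated time of 48 h (on this read-out higher numbers stand for weaker inhibition and lower numbers for stronger inhibition), and is the only compound in the set with a number rather than a limit. Compound 1 `N#CC1=C(N)Oc2c(c3nc4ccccc4nc3c3ccccc23)C12C(=O)N(Cc1cnnn1-c1ccccc1Br)c1ccccc12` sits at the limit of > 50000 nM in this assay. Compound 2 `CCOc1ccc(-n2nncc2CN2C(=O)C3(C(C#N)=C(N)Oc4c3c3nc5ccccc5nc3c3ccccc43)c3ccccc32)cc1` likewise sits at the limit of > 50000 nM in this assay. Both limits are summarised by the limit of > 50000 nM in this assay, at which 2 of the 3 values shown sit. The steps to the sulfamoyl compound were an at least 2.3-fold lower number from compound 1 to compound 3 (0.36 log units; beyond the scatter) and an at least 2.3-fold lower number from compound 2 to compound 3 (0.36 log units; beyond the scatter), while a step that the two limits leave unreadable from compound 1 to compound 2. Compound 4 `N#CC1=C(N)Oc2c(c3nc4ccccc4nc3c3ccccc23)C12C(=O)N(Cc1cnnn1-c1ccc(F)c(Cl)c1)c1ccccc12` carries 3-chloro-4-fluorophenyl in place of 3-sulfamoylphenyl on an aromatic nitrogen. Since both aryls lacking the sulfamoyl group, in compounds 1 and 2, sat at the limit, the change is expected to reverse those steps, giving a 2.3-fold higher number from compound 3 to compound 4 (0.37 log units; beyond the scatter). Compound 4 is therefore expected near 50000 nM, between 18000 nM and 150000 nM, most likely again a limit.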

Compound 4, half-maximal inhibitory concentration: > 50000 nM
Compound 4: a limit, no number (the forecaster's own chance of this, stated with the estimate: 60%); the middle value sits exactly at the limit.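

In this assay, 3-chloro-4-fluorophenyl in place of 3-sulfamoylphenyl on the aromatic nitrogen gives an at least 2.3-fold higher number from compound 3 to compound 4 (0.36 log units; beyond the scatter), so a doubly halogenated aryl also fails to give a number at this position. Only compound 3 now gives a number, and the steps among compound 1, compound 2 and compound 4 cannot be read, as all three stand at a limit of the assay: the limit of > 50000 nM in this assay, at which 3 of the 4 values shown sit.

Still open, going by these compounds, is whether a 3-carboxyphenyl or a 3-aminophenyl at this position would also give a number. On these data alone, whether a 4-sulfamoylphenyl would give one is equally open.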